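Swapping the pyrazolyl for thiazolyl in a sulfonylurea series

The source may report more compounds than this note shows. Statements on the series, on what has been measured and on what is new or still open speak of the compounds shown alone.

The study gathers three measured sulfonylureas and one still to be tested, all read in a functional assay on the whole organism (blood) with Rattus norvegicus as the target, with stated times of 24 h and 1 h, at a dose of 5 mg/kg by the intraperitoneal route; a higher number here means a stronger effect of the compound at the dose given, a lower number a weaker effect. Compound 1 `COc1ccc(Cl)cc1C(=O)NCC1CCN(S(=O)(=O)NC(=O)NC[C@@H]2C[C@@H]3C=C[C@@H]2C3)CC1` gives 15%. Compound 2 `COc1ccc(Cl)cc1C(=O)NCCC1CCN(S(=O)(=O)NC(=O)NN2CCCCCC2)CC1` gives 36%. Compound 3 `CCCNC(=O)NS(=O)(=O)N1CCC(CCNC(=O)c2cc(C(F)(F)F)nn2C)CC1` gives 11%, the lowest of the three numbers; the gap to compound 1 lies within the scatter of the method, while compound 2 sits beyond it. Going by the values given here, no pair among the measured compounds differs in only one place, so no single change can yet be tied to a step in this assay.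

Compound 4 `CCCNC(=O)NS(=O)(=O)N1CCC(CCNC(=O)c2cscn2)CC1` differs from compound 3 in one place: 1,3-thiazol-4-yl in place of 1-methyl-3-(trifluoromethyl)-1H-pyrazol-5-yl on a carbonyl carbon. The shared core of compound 3 and compound 4 is otherwise unchanged. Nothing measured speaks to this swap, so the step from compound 3 to compound 4 is expected to stay within the scatter, with no preferred direction. Compound 4 is therefore expected to give about 12% in this assay, in a range from 3% to 28%. The expected step is a number 1 percentage points higher from compound 3 to compound 4 (within the scatter).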

Compound 4, a percentage reported as activity, at one dose (the size of the read-out at that dose, not a potency): 10%
Compound 4: the middle estimate sits 2 percentage points above what was measured, within the range that was stated.
By their numbers in this assay, from the lowest: compounds 4, 3 and 1 (each within the scatter of the next); then compound 2.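

In this assay, going by these compounds alone, replacing 1-methyl-3-(trifluoromethyl)-1H-pyrazol-5-yl with 1,3-thiazol-4-yl on a carbonyl carbon whose other neighbour is an amide-type nitrogen gives a number 1 percentage points lower from compound 3 to compound 4 (within the scatter), the first step here that can be tied to a single change. The group that leaves has 10 heavy atoms and the one that enters has 5, while both are one five-membered aromatic ring with 2 hetero atoms, so in this pair the change in ring and the loss of the methyl and trifluoromethyl groups together produce no step beyond the scatter. No measurement bears on why the two compounds read alike, and the result is therefore recorded without an explanation.

As far as these compounds go, whether a phenyl ring, a cyclohexyl group or a group carrying a carboxylic acid at this place would also leave the read-out within the scatter remains open. From the compounds shown here alone, it is also open whether the same swap would read alike on the core of compound 2, since this single step comes from one pair on the core of compound 3.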